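Swapping Acetyl for Bromo: What to Expect for Compound 4

A few compounds are considered here, and "the series" means these few. Any claim that something is new, unique, unknown or untested is made for them only; others in the source may bear on it.

Three compounds share one core and differ only in a single group on the phenyl ring that hangs from it. Compound 1 `c1ccc(-c2cn3ccnc3c(-c3ccc4ncn(C5CCCCC5)c4c3)n2)cc1` carries hydrogen there, compound 2 `COc1ccc(-c2cn3ccnc3c(-c3ccc4ncn(C5CCCCC5)c4c3)n2)cc1` a methoxy, and compound 3 `CC(=O)c1ccc(-c2cn3ccnc3c(-c3ccc4ncn(C5CCCCC5)c4c3)n2)cc1` an acetyl. In a functional assay on MDA-MB-435 cells (Homo sapiens) for inhibition, read by sulforhodamine B assay, with a stated time of 48 h, tested at 10 uM (on this read-out higher numbers stand for more inhibition at the one concentration tested (going by the name of the read-out) and lower numbers for less inhibition), compound 1 gives 28.7%, compound 2 gives -18.6%, and compound 3 gives 6%. Among these three numbers compound 3 stands second highest: the step of a number 22.7 percentage points lower from compound 1 to compound 3 (beyond the scatter) places it beneath compound 1, while the step of a number 24.6 percentage points higher from compound 2 to compound 3 (beyond the scatter) places it above compound 2. The unmeasured compound 4 `Brc1ccc(-c2cn3ccnc3c(-c3ccc4ncn(C5CCCCC5)c4c3)n2)cc1` alters this same group once more: bromo in place of acetyl on an aromatic carbon. Both measured steps involve the acetyl group and so bear on this change, and both were modest in size. Neither involves a bromo group, so a direct precedent is missing. The step of a number 22.7 percentage points lower from compound 1 to compound 3 (beyond the scatter) ran downward when acetyl replaced hydrogen, so removing the acetyl again may recover part of that loss. Bromo itself is untested, so the expectation for compound 4 is a rise of about a number 14 percentage points higher from compound 3 to compound 4 (beyond the scatter), held loosely. Compound 4 is therefore estimated at 20%, within a range from -10% to 45%.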

Compound 4, a percentage reported as inhibition, at one concentration (the size of the read-out at that concentration, not a potency): 58.4%
Estimate against measurement, compound 4: 38.4 percentage points below, outside the stated range (above it).
By their numbers in this assay, from the lowest: compound 2; then compound 3; then compound 1; then compound 4.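

This position does not simply lose inhibition whenever hydrogen is replaced: in this assay, methoxy and acetyl both lowered the number, but bromo gives a number 29.7 percentage points higher from compound 1 to compound 4 (beyond the scatter). The choice of group therefore matters more than the presence of a group, as the swaps to bromo show, with a number 52.4 percentage points higher from compound 3 to compound 4 (beyond the scatter) and a number 77 percentage points higher from compound 2 to compound 4 (beyond the scatter). Nothing measured here explains why bromo behaves so differently from the other two groups.

On these data alone, it remains open whether chloro or fluoro in the same place would track bromo, or whether an amine or a carboxylic acid would instead fall with methoxy and acetyl. A reading at one concentration also leaves open how potent compound 4 is.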